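Working Notes: Methoxy Additions and Inhibition Readings

The compounds below may be only part of what the source reports. "The series", "measured", "known", "first", "only" and "open" are said of these compounds alone.

Compound 1 `COc1ccc(/C(Cl)=C/C=C(\C#N)C(=O)c2c[nH]c3ccccc23)cc1` is the reference point of the set. In a functional assay for inhibition, read by Griess assay, with a stated time of 150 min, tested at 1 mM (a higher number here means more inhibition at the concentration tested (going by the name of the read-out), a lower number less inhibition), compound 1 gives 76.9%. Compound 2 `COc1ccc(/C(Cl)=C/C=C(\C#N)C(=O)c2c[nH]c3ccc(OC)cc23)cc1` carries one change against compound 1, (methoxy in place of hydrogen on an aromatic carbon), and the step of a number 35.3 percentage points lower from compound 1 to compound 2 (beyond the scatter). Compound 3 `COc1ccc(/C(Cl)=C/C=C(\C#N)C(=O)c2c(C)[nH]c3ccccc23)cc1OC` differs from compound 1 in more than one place, so the difference between the two cores is not broken down here. In this assay compound 3 gives 75.8%, a value within the scatter of the value of compound 1, whereas compound 2 gives 41.6%, which lies beyond the scatter below both.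

Compound 4 `COc1cc(/C(Cl)=C/C=C(\C#N)C(=O)c2c(C)[nH]c3ccccc23)cc(OC)c1OC` is not yet measured. Against compound 3 the change is methoxy in place of hydrogen on an aromatic carbon. For the measured compounds named here, this is the same kind of change as the one made from compound 1 to compound 2, but the place is not the same: in compound 2 the entering methoxy sits on a six-membered aromatic ring of carbon only that is part of a fused or bridged system of two rings, meta to a fused ring and para to a fused ring; in compound 4 it sits on a six-membered aromatic ring of carbon only, ortho to a methoxy group, meta to a large group and meta to a methoxy group.

Going by the values given here, the only measured step of this kind, a number 35.3 percentage points lower from compound 1 to compound 2 (beyond the scatter), was a large loss, and it is the sole direct guide, though it occurred at another place. Compound 4 is expected to lose inhibition, with the expected step being a number 17.8 percentage points lower from compound 3 to compound 4 (beyond the scatter). The estimate for compound 4 is 58%, with an expected range from 30% to 80%.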

Compound 4, a percentage reported as inhibition, at one concentration (the size of the read-out at that concentration, not a potency): 74.2%
Compound 4: the middle estimate sits 16.2 percentage points below what was measured, and the stated range covers the measured number.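

Adding methoxy in place of hydrogen on an aromatic carbon gave, in this assay, a number 1.6 percentage points lower from compound 3 to compound 4 (within the scatter), so the large loss seen with the same kind of change in a number 35.3 percentage points lower from compound 1 to compound 2 (beyond the scatter) does not carry over as a fixed penalty for this change across the series. Set side by side, the two steps do not agree: the same change on two cores in this assay, a number 35.3 percentage points lower (beyond the scatter) from compound 1 to compound 2 and a number 1.6 percentage points lower (within the scatter) from compound 3 to compound 4, 33.7 percentage points apart, beyond the scatter of two such steps

What this does not show is why they differ, since the two steps change both the core and the place where the methoxy enters, and the pair cannot separate one from the other; on two steps alone, no rule can be stated for either core, and each reading is a single-concentration figure rather than a potency.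

The compounds shown leave open whether the methoxy would cost as much on the core of compound 3 at the place it occupies in compound 2, and whether the loss would recur on the core of compound 1 at the place it occupies in compound 4. They also leave open how an amine, a carboxylic acid or a longer chain such as butoxy would read in this assay at the place on the ring that takes the methoxy in compound 4.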